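The source may report more compounds than this note shows. Statements on the series, on what has been measured and on what is new or still open speak of the compounds shown alone.

Working notes on the series. The shared core is that of compound 1 `Cc1ccc(S(=O)(=O)c2nc3ccccc3nc2N2CCCC2)cc1`. In a functional assay on PC-3 cells (Homo sapiens) for cytotoxicity, read by MTT assay, with a stated time of 72 h (a lower number here means a stronger inhibitor, a higher number a weaker inhibitor), compound 1 gives only a limit, > 50000 nM. Compound 2 `O=S(=O)(c1ccc(F)cc1)c1nc2ccccc2nc1N1CCCC1` gives 12400 nM in this assay, and compound 3 `Cc1ccc(S(=O)(=O)c2nc3ccccc3nc2N2CCc3ccccc3C2)cc1` gives 22400 nM. Of the two numbers in hand, the value of compound 3 stands highest, with compound 2 nearest; the gap between these two values lies within the scatter, so no order between them can be read. The measured steps are an at least 4.0-fold lower number from compound 1 to compound 2 (0.60 log units; beyond the scatter) and an at least 2.2-fold lower number from compound 1 to compound 3 (0.34 log units; beyond the scatter); both start from the limit of > 50000 nM in this assay, at which 1 of the 3 values shown sits, so their true size is known only as a lower bound.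

Compound 4 `O=S(=O)(c1ccc(F)cc1)c1nc2ccccc2nc1N1CCc2ccccc2C1` is not yet measured. It differs from compound 3 in one place: fluoro in place of methyl on an aromatic carbon. The only measured case of this exchange is the step of an at least 4.0-fold lower number from compound 1 to compound 2 (0.60 log units; beyond the scatter), which bears directly on the present step because the limit of > 50000 nM in this assay, at which 1 of the 3 values shown sits, hides how much of that change lies beyond the bound. A step of similar direction is therefore expected here, and compound 4 is estimated to lower the number by a 4.0-fold lower number from compound 3 to compound 4 (0.60 log units; beyond the scatter) in this assay. On that basis compound 4 is expected to give about 5600 nM, with a range from 2000 nM to 15000 nM.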

Compound 4, half-maximal inhibitory concentration: 9230 nM
Compound 4: middle estimate off by 1.6-fold (0.22 log units), on the low side, within the range that was stated.
By their numbers in this assay, from the lowest: compounds 4, 2 and 3 (each within the scatter of the next, the first and the last beyond it). At a limit, above all of these: compound 1.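

With fluoro in place of methyl on an aromatic carbon para to a large group, this assay now gives a step with a measured value at both ends, a 2.4-fold lower number from compound 3 to compound 4 (0.39 log units; beyond the scatter), and the direction of this exchange is the same on both cores: the same change on two cores in this assay, an at least 4.0-fold lower number (0.60 log units; beyond the scatter) from compound 1 to compound 2 and a 2.4-fold lower number (0.39 log units; beyond the scatter) from compound 3 to compound 4; the limit leaves it open whether they differ With 1,2,3,4-tetrahydroisoquinolin-2-yl in place of pyrrolidin-1-yl, the new step on the 4-fluorophenyl side is a 1.3-fold lower number from compound 2 to compound 4 (0.13 log units; within the scatter), so the two groups cannot be told apart with 4-fluorophenyl present, and no comparison can be made with the corresponding step on the 4-methylphenyl side: the same change on two cores in this assay, an at least 2.2-fold lower number (0.34 log units; beyond the scatter) from compound 1 to compound 3 and a 1.3-fold lower number (0.13 log units; within the scatter) from compound 2 to compound 4; the limit leaves it open whether they differ Compound 1 remains a limit, > 50000 nM, and not a number.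

The compounds shown leave open whether a chloro, methoxy or trifluoromethyl group on that aromatic carbon would continue the step seen with fluoro. It is also open whether a morpholin-4-yl or piperazin-1-yl group in place of pyrrolidin-1-yl would separate from the two groups shown on the 4-fluorophenyl side.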